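Methylating a hydroxy group at the assay limit

This account rests on a few compounds, and the source may have more. Where it says the series, first, only, none or still open, it means among the compounds named here.

Measured in a functional assay on L5178Y cells (Mus musculus) for inhibition, read by MTT assay, with a stated time of 24 h; a higher number here means a weaker inhibitor, a lower number a stronger inhibitor:
compound 1 `COc1cc(O)c2c(c1)O[C@H](c1ccc(O)cc1)C/C2=N\Nc1ccccc1`: >= 11300 nM
compound 2 `COc1cc(O)c2c(c1)O[C@H](c1ccc(O)cc1)C/C2=N\NC(=O)c1ccco1`: >= 11300 nM
compound 3 `COc1cc(O)c2c(c1)O[C@H](c1ccc(O)cc1)C/C2=N\NC(=O)OCc1ccccc1`: >= 11300 nM

Compound 1 stands only at a limit (>= 11300 nM) and not at a number. The same holds across the whole set (the limit of >= 11300 nM in this assay, at which 3 of the 3 values shown sit). Compound 4 `COc1ccc([C@@H]2C/C(=N\Nc3ccccc3)c3c(O)cc(OC)cc3O2)cc1` differs from compound 1 by a single change methyl in place of hydrogen on an oxygen on an aromatic ring in the form of methyl in place of hydrogen on an oxygen on an aromatic ring, hydroxy to methoxy. The measured steps (a step that the two limits leave unreadable from compound 1 to compound 2; a step that the two limits leave unreadable from compound 1 to compound 3; a step that the two limits leave unreadable from compound 2 to compound 3) change a different group and have no readable size. No step beyond the scatter is therefore expected in this assay, and no direction is favoured. The expected step (a step that the limit leaves unreadable from compound 1 to compound 4) may again end at a limit. Compound 4 is estimated at 15000 nM (expected range 6000 nM to 40000 nM) in this measurement.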

Compound 4, half-maximal inhibitory concentration: >= 11300 nM
Compound 4: only a limit was reported; the forecaster's own chance of this, stated with the estimate: 65%; the middle value is on the limit's open side.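

The step between compound 1 and compound 4 cannot be read, because both are reported only as a limit in this assay: the limit of >= 11300 nM in this assay, at which 4 of the 4 values shown sit.

Whether swapping hydroxy for methoxy changes inhibition at all, and how strongly any of the compounds shown inhibit, stays open.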